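Amide nitrogen substituent in an aryloxyacetamide series

This account rests on a few compounds, and the source may have more. Where it says the series, first, only, none or still open, it means among the compounds named here.

Working notes on two measured compounds and one awaiting measurement. In an assay on HEK293 cells for agonist activity at transient receptor potential cation channel subfamily M member 8 (Homo sapiens), read by fluorescence and calcium flux, with a stated time of 15 min (on this read-out higher numbers stand for an effect only at larger amounts of compound and lower numbers for an effect already at smaller amounts), compound 2, `Cc1ccc(OCC(=O)N(Cc2cccs2)c2c[nH]nc2C)cc1`, gives 0.4 nM, the lowest of the two numbers in hand. Going by the values given here, its nearest neighbour is compound 1, `CCN(Cc1ccoc1)C(=O)COc1ccc(C)cc1`, which in this assay gives 136 nM, a far higher number and well beyond the scatter; no single-change step joins these two, so only the two values are noted here. Compound 1 carries ethyl and furanylmethyl on its amide nitrogen, compound 2 a heteroaryl group and thienylmethyl.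

Compound 3, `Cc1ccc(OCC(=O)N(C)Cc2cccs2)cc1`, differs from compound 2 at one place: methyl in place of 3-methyl-1H-pyrazol-4-yl on an amide-type nitrogen. The group that leaves carries the only hydrogen-bond donor of the pair, and compound 3 moves toward the small-alkyl pattern of compound 1. Among the compounds with values here, with no measured step of this kind to lean on, the step in this assay is expected to be large and toward higher numbers, because compound 1 with its small alkyl on the amide nitrogen gives 136 nM. Compound 3 is therefore expected to give about 100 nM, in the range 12 nM to 900 nM, a step of a 250-fold higher number from compound 2 to compound 3 (2.40 log units; beyond the scatter).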

Compound 3, half-maximal effective concentration: 400 nM
For compound 3 the middle estimate is 4.0-fold (0.60 log units) below the measured one, within the range that was stated.
By their numbers in this assay, from the lowest: compound 2; then compound 1; then compound 3.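

In this assay, going by these compounds alone, methyl in place of 3-methyl-1H-pyrazol-4-yl on an amide-type nitrogen gives a 1000-fold higher number from compound 2 to compound 3 (3.00 log units; beyond the scatter), the only single-change step so far. Compounds 1 and 2 differ in more than one place and could not isolate this nitrogen substituent, whereas here the thienylmethyl group and the rest of the molecule stay fixed, so the number in this assay is shown to be highly sensitive to the group at this position. The ring, the hydrogen-bond donor, the hydrogen-bond acceptor and the extra heavy atoms all leave together in this one change, and nothing available bears on the cause of the step.

The compounds shown leave open whether a phenyl ring at this position would keep a low number, and whether a pyrazole with methyl in place of the ring nitrogen's hydrogen would do the same. They also leave open how a longer chain such as propyl would compare with methyl on this nitrogen, with the thienylmethyl group retained.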